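Imidazole to aminothiazole on the shared core: expected stability

This account rests on a few compounds, and the source may have more. Where it says the series, first, only, none or still open, it means among the compounds named here.

Measured compounds:
- compound 1, `CC(C)C(c1ncc[nH]1)c1ccc(-c2ccc3cccc(F)c3c2)[nH]c1=O`, gives < 0.0667 h in an ADME assay on microsomes from liver (Mus musculus) for metabolic stability; a lower number here means that the compound disappears faster, a higher number that the compound lasts longer
- compound 2, `CC(C)C(Cc1nnn[nH]1)c1ccc(-c2ccc3cccc(F)c3c2)[nH]c1=O`, gives 0.853 h in this assay
- compound 3, `CC(C)C(c1ccc(-c2ccc3cccc(F)c3c2)[nH]c1=O)N1CCCCS1(=O)=O`, gives 0.0733 h in this assay

For the measured compounds named here, compound 1 stands at a limit of the assay rather than at a number; the limit of < 0.0667 h in this assay, at which 1 of the 3 values shown sits, records that it is the one value of the three that sits there. From compound 1 to compound 2, where an at least 12-fold higher number from compound 1 to compound 2 (1.10 log units; beyond the scatter), the number rose clearly, whereas from compound 1 to compound 3 only an at least 1.0-fold higher number from compound 1 to compound 3 (0.04 log units; that floor lies within the scatter) is seen. Compound 2 against compound 3 shows a 12-fold lower number from compound 2 to compound 3 (1.07 log units; beyond the scatter).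

Compound 4, `CC(C)C(c1cnc(N)s1)c1ccc(-c2ccc3cccc(F)c3c2)[nH]c1=O`, is not yet measured. It differs from compound 1 by 2-amino-1,3-thiazol-5-yl in place of 1H-imidazol-2-yl on a saturated chain carbon bound to an aromatic carbon and a saturated chain carbon. Both steps away from compound 1 bear on this change, since each also swaps the group on that saturated chain carbon. One gave a large rise, the other nothing that can be told from the scatter. Because compound 1 sits at < 0.0667 h, any movement can only be recorded upward. The expectation for compound 4 is a modest step, an at least 1.4-fold higher number from compound 1 to compound 4 (0.17 log units; that floor lies within the scatter), with a real chance that only a limit is reported again. Compound 4 is thus estimated at 0.1 h, within 0.04 h to 0.3 h.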

Compound 4, half-life: 0.08 h
Beside the measured number, compound 4's estimate is 1.3-fold (0.10 log units) above it, within the range that was stated.
By their numbers in this assay, from the lowest: compounds 3 and 4 (each within the scatter of the next); then compound 2. At a limit, below all of these: compound 1.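

Compound 1 stands at a limit of the assay in this assay: the limit of < 0.0667 h in this assay, at which 1 of the 4 values shown sits. The swap of 1H-imidazol-2-yl for 2-amino-1,3-thiazol-5-yl on this saturated chain carbon gives an at least 1.1-fold higher number from compound 1 to compound 4 (0.07 log units; that floor lies within the scatter), so the size of this step cannot be read. The 2-amino-1,3-thiazol-5-yl group and the six-membered non-aromatic ring of compound 3 cannot be told apart on this saturated chain carbon, with a 1.1-fold higher number from compound 3 to compound 4 (0.04 log units; within the scatter), even though one ring is aromatic and the other is not. The third comparison, an 11-fold lower number from compound 2 to compound 4 (1.03 log units; beyond the scatter), shows that a second aromatic five-membered ring on this carbon does not reproduce the number of compound 2, which leaves the (1H-tetrazol-5-yl)methyl group of compound 2 as the only group shown that stands clearly apart from the others.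

Going by these compounds, compound 2 differs from the others both in its ring and in the methyl link, so it remains open which of the two carries the large step. A 1H-tetrazol-5-yl bound directly to the chain carbon, or a carboxylic acid on a methyl link, would help to separate these two parts.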